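From vinyl to cyclopropyl on a shared core

This account rests on a few compounds, and the source may have more. Where it says the series, first, only, none or still open, it means among the compounds named here.

Measured in a functional assay on MCF7 cells (Homo sapiens) for inhibition, read by resazurin assay, with a stated time of 72 h; on this read-out higher numbers stand for weaker inhibition and lower numbers for stronger inhibition:
compound 1 `C=CC1C(=O)N(c2cc(OC)c(OC)c(OC)c2)C1c1ccc(SC)cc1`: 51 nM
compound 2 `C=CC1C(=O)N(c2cc(OC)c(OC)c(OC)c2)C1c1ccc(SCC)cc1`: 181 nM
compound 3 `C=CC1C(=O)N(c2cc(OC)c(OC)c(OC)c2)C1c1ccc(OC)cc1`: 17 nM

Of these three, compound 1 holds the second highest number at 51 nM, so it sits in the middle. Compound 4 `COc1cc(N2C(=O)C(C3CC3)C2c2ccc(SC)cc2)cc(OC)c1OC` differs from compound 1 in one place, with cyclopropyl in place of vinyl on a saturated ring carbon.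

For the measured compounds named here, no measured step touches that place. Going by the values given here, the only guides are changes elsewhere in the molecule. The step of a 3.5-fold higher number from compound 1 to compound 2 (0.55 log units; beyond the scatter) and the step of a 3.0-fold lower number from compound 1 to compound 3 (0.48 log units; beyond the scatter) are both modest, while the step of an 11-fold lower number from compound 2 to compound 3 (1.03 log units; beyond the scatter) is large. These show that single changes can move the number in either direction in this small set, but they say nothing about the new group. A step beyond the scatter is therefore not expected in this assay, and the data give no firm direction. The estimated change is a 1.2-fold higher number from compound 1 to compound 4 (0.07 log units; within the scatter). For compound 4 the expected value is 60 nM, with an estimated range of 20 nM to 180 nM.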

Compound 4, half-maximal inhibitory concentration: 131 nM
For compound 4 the middle estimate is 2.2-fold (0.34 log units) below the measured one; low and high end bracket the measured number.
By their numbers in this assay, from the lowest: compound 3; then compound 1; then compounds 4 and 2 (each within the scatter of the next).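

For the compounds shown here, this is the first measured change at the saturated ring carbon that carries the vinyl group, and in this assay the position proves sensitive to it, with a 2.6-fold higher number from compound 1 to compound 4 (0.41 log units; beyond the scatter) as cyclopropyl replaces vinyl. A three-membered ring of carbon only, in place of a double bond outside aromatic rings, therefore gives a higher number and so weaker inhibition on the core of compound 1. Nothing measured here accounts for this shift, so its cause remains unknown.

On these data alone, whether the same swap would move the number in the same direction alongside the methoxy group of compound 3 or the ethylsulfanyl group of compound 2 stays open. How an ethyl, hydroxymethyl or aminomethyl group would compare at this ring carbon also remains unknown from the compounds shown.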